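Amine Substituent Variation Within the Shared Core Series

The source may hold more compounds than are shown below. What is called first, only, known or untested is meant among the compounds shown, and "the series" means these compounds.

Within the data shown here, compound 2 `C=CCNC(=C\C(=O)/C=C/c1ccc(O)c(OC)c1)/C=C/c1ccc(O)c(OC)c1` is the one member of the set with a number rather than a limit: in a functional assay on HT-29 cells (Homo sapiens) for inhibition, read by sulforhodamine B assay, with a stated time of 72 h (on this read-out lower numbers stand for stronger inhibition and higher numbers for weaker inhibition), compound 2 gives 24600 nM. Compound 1 `CCCNC(=C\C(=O)/C=C/c1ccc(O)c(OC)c1)/C=C/c1ccc(O)c(OC)c1` reaches only the limit of the assay, > 25000 nM in this assay. Compound 3 `COc1cc(/C=C/C(=O)/C=C(/C=C/c2ccc(OC(C)=O)c(OC)c2)NCC(C)C)ccc1OC(C)=O` likewise sits at the limit, > 25000 nM in this assay. Compound 4 `CCC(C)NC(=C\C(=O)/C=C/c1ccc(O)c(OC)c1)/C=C/c1ccc(O)c(OC)c1` is not yet measured; it differs from compound 2 by sec-butyl in place of allyl on an amine nitrogen. Among the measured compounds shown here, the one measured step that bears on this change, an at least 1.0-fold lower number from compound 1 to compound 2 (0.00 log units; that floor lies within the scatter), lies within the scatter, and the limit of > 25000 nM in this assay, at which 2 of the 3 values shown sit, shows how close the whole set sits to that ceiling. For compound 4 no step beyond the scatter is expected, a 1.2-fold higher number from compound 2 to compound 4 (0.09 log units; within the scatter), with a fair chance that only a limit is returned. Compound 4 is therefore estimated at 30000 nM, within 12000 nM to 80000 nM.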

Compound 4, half-maximal inhibitory concentration: 22300 nM
Compound 4: middle estimate off by 1.3-fold (0.13 log units), on the high side; low and high end bracket the measured number.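

In this assay, sec-butyl and allyl on the amine nitrogen are not told apart, and this comparison joins two numbers rather than a limit: a 1.1-fold lower number from compound 2 to compound 4 (0.04 log units; within the scatter). The other new step, an at least 1.1-fold lower number from compound 1 to compound 4 (0.04 log units; that floor lies within the scatter), rests on a limit, so it gives only a floor and fixes no size. Neither step moves the series clear of the assay ceiling: the limit of > 25000 nM in this assay, at which 2 of the 4 values shown sit.

Still open, on these data alone, is whether a benzyl group or a longer chain ending in a carboxylic acid on this nitrogen would give a number clearly away from that limit.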